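Two Diaryl Methanes Sharing One Substitution

The source may hold more compounds than are shown below. What is called first, only, known or untested is meant among the compounds shown, and "the series" means these compounds.

The series consists of bis-indolyl methanes carrying a single aryl group on the central carbon. Compound 1 `Cc1ccc(C(c2c[nH]c3ccccc23)c2c[nH]c3ccccc23)cc1` and compound 2 `Fc1cc(F)cc(C(c2c[nH]c3ccccc23)c2c[nH]c3ccccc23)c1` share one core; compound 3 `Cc1ccc(C(c2c[nH]c3ccc(I)cc23)c2c[nH]c3ccc(I)cc23)cc1` and the still unmeasured compound 4 `Fc1cc(F)cc(C(c2c[nH]c3ccc(I)cc23)c2c[nH]c3ccc(I)cc23)c1` share another, and the difference between the two cores is not broken down here.

In a functional assay on ME18 cells (Homo sapiens) for cytotoxicity, read by MTT assay, with a stated time of 48 h (on this read-out lower numbers stand for stronger inhibition and higher numbers for weaker inhibition), compound 1 gives 46700000 nM. Compound 2 differs from compound 1 by 3,5-difluorophenyl in place of 4-methylphenyl on a saturated chain carbon bound to two aromatic carbons. In this assay compound 2 gives 31100000 nM. The step of a 1.5-fold lower number from compound 1 to compound 2 (0.18 log units; within the scatter) is therefore small. Compound 3 gives 22600000 nM in this assay; against compound 1 this is the larger gap, while against compound 2 the two numbers cannot be told apart.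

Compound 4 differs from compound 3 by 3,5-difluorophenyl in place of 4-methylphenyl on a saturated chain carbon bound to two aromatic carbons. For the measured compounds named here, this is the same change as the one from compound 1 to compound 2, made on the same kind of carbon, so the only guide to its size is that earlier step. Because a 1.5-fold lower number from compound 1 to compound 2 (0.18 log units; within the scatter) lies within the scatter, the step of a 1.4-fold lower number from compound 3 to compound 4 (0.15 log units; within the scatter) is expected to be equally modest, with the new core adding no known effect. Compound 4 is thus estimated at 16000000 nM in this assay, with a range from 7000000 nM to 35000000 nM to allow for the usual spread of such measurements and the small number of compounds on which this expectation rests.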

Compound 4, half-maximal inhibitory concentration: 21300000 nM
Compound 4: the middle estimate sits 1.3-fold (0.12 log units) below what was measured; the measured number falls inside the stated range.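

In this assay, putting 3,5-difluorophenyl in place of 4-methylphenyl on the core of compound 3 gives a 1.1-fold lower number from compound 3 to compound 4 (0.03 log units; within the scatter), so on this core too the change leaves the number where it was, to within the scatter. Set side by side, the two steps cannot be told apart, and in this small set the change carries from one core to the other as a step that stays small on both: the same change on two cores in this assay, a 1.5-fold lower number (0.18 log units; within the scatter) from compound 1 to compound 2 and a 1.1-fold lower number (0.03 log units; within the scatter) from compound 3 to compound 4, 1.4-fold (0.15 log units) apart, within the scatter of two such steps. For the compounds shown here, this rests on one pair of compounds per core and shows only that neither core reveals a measurable effect of the change; it does not show that the change would stay small on a further core, and it says nothing of how the two cores themselves compare.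

The compounds shown leave open whether an amine, a carboxylic acid or a longer chain in place of these two aryl groups on the saturated chain carbon would give a step beyond the scatter. They also leave open whether the same small step would appear on a core carrying chlorine or a methoxy group where the core of compound 3 carries iodine.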